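The source may report more compounds than this note shows. Statements on the series, on what has been measured and on what is new or still open speak of the compounds shown alone.

Compound 1 `O=C(O)c1cc(-c2cncs2)ccc1O` carries a 1,3-thiazol-5-yl group on the shared core. In a functional assay on the whole organism for inhibition, with Rattus norvegicus as the target, read by paw edema (on this read-out higher numbers stand for an effect only at larger amounts of compound and lower numbers for an effect already at smaller amounts), compound 1 gives > 200 mg/kg, which is a limit of the assay and not a number. Two measured compounds exchange that group. Compound 2 `O=C(O)c1cc(C2N=NN=N2)ccc1O` gives 110 mg/kg in this assay, and compound 3 `O=C(O)c1cc(-c2cccs2)ccc1O` gives 60 mg/kg. The step of an at least 1.8-fold lower number from compound 1 to compound 2 (0.25 log units; that floor lies within the scatter) and the step of an at least 3.3-fold lower number from compound 1 to compound 3 (0.52 log units; beyond the scatter) both start from the limit at which compound 1 sits, (the limit of > 200 mg/kg in this assay, at which 1 of the 3 values shown sits), so each tells only the floor of the change. Between the two measured exchanges there is a 1.8-fold lower number from compound 2 to compound 3 (0.26 log units; within the scatter). Compound 4 `O=C(O)c1cc(-n2cncn2)ccc1O` has not yet been measured in this assay. It differs from compound 1 in one place: 1H-1,2,4-triazol-1-yl in place of 1,3-thiazol-5-yl on an aromatic carbon. Both measured exchanges of the 1,3-thiazol-5-yl group moved the number off the limit to a lower value, so for compound 4 a lower number is expected as well, with an at least 2.0-fold lower number from compound 1 to compound 4 (0.30 log units; that floor lies within the scatter) as the estimated size of the step. Compound 4 is therefore estimated to give about 100 mg/kg, with a range from 50 mg/kg to 200 mg/kg.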

Compound 4, dose for half-maximal effect: 200 mg/kg
The estimate for compound 4 lay 2.0-fold (0.30 log units) below the measured number; low and high end bracket the measured number.
By their numbers in this assay, from the lowest: compounds 3, 2 and 4 (each within the scatter of the next, the first and the last beyond it).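

The position para to a hydroxy group does not treat all five-membered aromatic rings alike in this assay, as 1H-1,2,4-triazol-1-yl in place of thiophen-2-yl gives, as a modest step, a 3.3-fold higher number from compound 3 to compound 4 (0.52 log units; beyond the scatter) on the shared core. The ring of compound 2 and the 1H-1,2,4-triazol-1-yl group cannot be told apart, with a 1.8-fold higher number from compound 2 to compound 4 (0.26 log units; within the scatter), so the thiophen-2-yl group alone stands clear of the 1H-1,2,4-triazol-1-yl group. Compound 1 sits at a limit, so the size of a number no higher from compound 1 to compound 4 (the limit leaves the size open) cannot be read: the limit of > 200 mg/kg in this assay, at which 1 of the 4 values shown sits.

All the compounds shown carry a five-membered ring at this position, which leaves open how a phenyl ring, a pyridyl ring or an amine would read in this assay. On these data alone, it also remains open whether a methyl group or a chlorine atom on the thiophen-2-yl ring of compound 3 would shift its number.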